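Working notes: from compound 3 to compound 4

The source may hold more compounds than are shown below. What is called first, only, known or untested is meant among the compounds shown, and "the series" means these compounds.

- compound 1 `CCCCCN1CCC(COC(c2ccccc2)c2ccccc2)CC1` gives 10800 nM
- compound 2 `CCCCCCCCN1CCC(COC(c2ccccc2)c2ccccc2)CC1` gives 700 nM
- compound 3 `C(#Cc1ccccc1)CN1CCC(COC(c2ccccc2)c2ccccc2)CC1` gives > 20000 nM (a limit, not a number)

In a functional assay on cells (T-cell line, Homo sapiens) for inhibition (on this read-out lower numbers stand for stronger inhibition and higher numbers for weaker inhibition), compound 3 is known only through its limit > 20000 nM. Compound 4 `c1ccc(C(OCC2CCN(CC3CCc4ccccc4C3)CC2)c2ccccc2)cc1` differs from it at one place: 1,2,3,4-tetrahydronaphthalen-2-yl in place of 2-phenylethynyl on a saturated chain carbon bound to an amine nitrogen in a ring. Going by the values given here, two measured steps bear most directly on this change: an at least 28-fold higher number from compound 2 to compound 3 (1.45 log units; beyond the scatter) and an at least 1.8-fold higher number from compound 1 to compound 3 (0.26 log units; that floor lies within the scatter), the floor of the latter lying within the scatter. The saturated chains also differ, with a 15-fold lower number from compound 1 to compound 2 (1.19 log units; beyond the scatter). Compound 4 lacks the triple bond, so a clear move towards a lower number is expected, smaller than the largest measured step. The expected step is an at least 4.0-fold lower number from compound 3 to compound 4 (0.60 log units; beyond the scatter). For compound 4 the estimate is 5000 nM, with an expected range from 1200 nM to 20000 nM.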

Compound 4, half-maximal inhibitory concentration: 5600 nM
The estimate for compound 4 lay 1.1-fold (0.05 log units) below the measured number, within the range that was stated.
By their numbers in this assay, from the lowest: compound 2; then compounds 4 and 1 (each within the scatter of the next). At a limit, above all of these: compound 3.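

In this assay, 1,2,3,4-tetrahydronaphthalen-2-yl at this place gives a measurable number where 2-phenylethynyl did not: an at least 3.5-fold lower number from compound 3 to compound 4 (0.55 log units; beyond the scatter). Set against butyl, the new group shows no change beyond the scatter, a 1.9-fold lower number from compound 1 to compound 4 (0.29 log units; within the scatter), while heptyl keeps the clearly lower number, an 8.0-fold higher number from compound 2 to compound 4 (0.90 log units; beyond the scatter). Compound 3 stands only as a limit: the limit of > 20000 nM in this assay, at which 1 of the 4 values shown sits.

Open, as far as these compounds go, is whether a chain longer than heptyl would lower the number further. Also open, from the compounds shown here alone, is whether a cyclohexyl group or a hydroxyl on the chain would match the 1,2,3,4-tetrahydronaphthalen-2-yl result.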